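Taking the nitro group off compound 2

A few compounds are considered here, and "the series" means these few. Any claim that something is new, unique, unknown or untested is made for them only; others in the source may bear on it.

Measured in a functional assay on MIA PaCa-2 cells (Homo sapiens) for cytotoxicity, read by MTT assay, with a stated time of 4 h; a lower number here means a stronger inhibitor, a higher number a weaker inhibitor:
Compound 1 `COC1=CC(=O)c2c(c(COc3ccncc3)c(C)n2C)C1=O` gives 2010 nM
Compound 2 `COC1=CC(=O)c2c(COc3ccc([N+](=O)[O-])cc3)c(C)n(C)c2C1=O` gives 638 nM

Compound 2 holds the lower of the two numbers, and the gap to compound 1 lies beyond the scatter. Compound 3 `COC1=CC(=O)c2c(COc3ccccc3)c(C)n(C)c2C1=O` has hydrogen in place of nitro on an aromatic carbon. Within the data shown here, no measured pair isolates this change. Compound 1, which also has no nitro, stands at the higher number (2010 nM), so a weaker inhibitor is expected, by a step beyond the scatter (a 3.1-fold higher number from compound 2 to compound 3 (0.50 log units; beyond the scatter)). The estimate for compound 3 is 2000 nM, within a range from 700 nM to 6000 nM.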

Compound 3, half-maximal inhibitory concentration: 4560 nM
Compound 3: middle estimate off by 2.3-fold (0.36 log units), on the low side; measured number inside the range.
By their numbers in this assay, from the lowest: compound 2; then compound 1; then compound 3.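

In this assay, among these compounds, the pair gives the first direct reading of the nitro group on this aromatic carbon: a 7.1-fold higher number from compound 2 to compound 3 (0.85 log units; beyond the scatter) and lies beyond the scatter. On the shared core, nitro at this place therefore goes with the lower number and hydrogen with the higher one. Nothing measured here accounts for the step.

The compounds shown leave open whether this belongs to nitro alone or would also appear with a nitrile, an amine or a carboxylic acid on the same carbon.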